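Removing the trifluoromethyl from compound 2

A few compounds are considered here, and "the series" means these few. Any claim that something is new, unique, unknown or untested is made for them only; others in the source may bear on it.

Among the measured compounds shown here, compound 2, with the structure `Cc1cc(Nc2ccn(Cc3ccc(C(F)(F)F)cc3)n2)n2nc(SCc3ccc(Br)cc3)nc2n1`, is the only member of this small set with a numerical result: in a functional assay on PC-9 cells (Homo sapiens) for inhibition, read by MTT assay, with a stated time of 72 h (on this read-out lower numbers stand for stronger inhibition and higher numbers for weaker inhibition), compound 2 gives 5580 nM. Compound 1, `Cc1ccc(Cn2ccc(Nc3cc(C)nc4nc(SCc5ccc(Br)cc5)nn34)n2)cc1`, reaches only the limit of this assay, namely > 50000 nM. Compound 3, `Cc1cc(Nc2cc(-c3ccccc3)[nH]n2)n2nc(SCC3CC3)nc2n1`, likewise stops at the limit of this assay, > 50000 nM. For the measured compounds named here, the one measured step is an at least 8.9-fold lower number from compound 1 to compound 2 (0.95 log units; beyond the scatter), and it is the only evidence that bears on the change now considered, since it concerns the same aromatic carbon.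

Compound 4, `Cc1cc(Nc2ccn(Cc3ccccc3)n2)n2nc(SCc3ccc(Br)cc3)nc2n1`, differs from compound 2 by hydrogen in place of trifluoromethyl on an aromatic carbon. Because the step of an at least 8.9-fold lower number from compound 1 to compound 2 (0.95 log units; beyond the scatter) shows that what sits on this carbon moves the number by a large amount, and because the limit of > 50000 nM in this assay, at which 2 of the 3 values shown sit, marks where two of the three compounds already rest, the removal of the trifluoromethyl is expected to weaken inhibition, with a real chance that compound 4 again reaches only that limit. Compound 4 is therefore estimated at 30000 nM, between 8000 nM and 120000 nM. The step this implies is expected to be a 5.4-fold higher number from compound 2 to compound 4 (0.73 log units; beyond the scatter).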

Compound 4, half-maximal inhibitory concentration: > 50000 nM
Compound 4: only a limit was reported; the forecaster's own chance of this, stated with the estimate: 45%; middle value at least 1.6-fold (0.22 log units) away from the limit.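

Replacing trifluoromethyl with hydrogen gives an at least 8.9-fold higher number from compound 2 to compound 4 (0.95 log units; beyond the scatter), so in this assay a benzyl group alone does not bring a measurable number on this core, and the substituent on this aromatic carbon is what separates compound 2 from compound 4. Of the three groups seen on this carbon, only trifluoromethyl gives a number; the step from methyl to hydrogen cannot be read, as compound 1 and compound 4 both stop at a limit. The printed step is therefore only a lower bound on the loss, because most of the set rests at one limit: the limit of > 50000 nM in this assay, at which 3 of the 4 values shown sit.

Going by these compounds, it remains open whether chlorine, a methoxy group or a nitrile on this carbon would also give a number. On these data alone, it is equally open whether a larger group, such as a trifluoromethoxy group, would lower the number beyond that of compound 2.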